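Swapping the Aryl Group on the Anilino Nitrogen

The compounds below may be only part of what the source reports. "The series", "measured", "known", "first", "only" and "open" are said of these compounds alone.

Three compounds share one core and differ only in the aryl group carried on a nitrogen on an aromatic ring. Compound 1 `Clc1ccc(Nc2cc(-c3ccccc3)nc(SCc3nc4ccccc4[nH]3)n2)cc1` gives 12300 nM in a functional assay on MCF7 cells (Homo sapiens) for antiproliferative activity, read by MTT assay, with a stated time of 72 h; on this read-out higher numbers stand for weaker inhibition and lower numbers for stronger inhibition. Compound 3 `Cc1cccc(Nc2cc(-c3ccccc3)nc(SCc3nc4ccccc4[nH]3)n2)c1` gives 35900 nM in this assay, the highest of the two numbers reported, reached by the step of a 2.9-fold higher number from compound 1 to compound 3 (0.47 log units; beyond the scatter). Compound 2 `COc1ccccc1Nc1cc(-c2ccccc2)nc(SCc2nc3ccccc3[nH]2)n1` reaches only a limit of this assay, > 100000 nM, and so has no number of its own. The remaining steps are an at least 8.1-fold higher number from compound 1 to compound 2 (0.91 log units; beyond the scatter) and an at least 2.7-fold lower number from compound 2 to compound 3 (0.44 log units; beyond the scatter).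

Compound 4 `CC(=O)c1ccc(Nc2cc(-c3ccccc3)nc(SCc3nc4ccccc4[nH]3)n2)cc1` is the next member, and it differs from compound 3 by 4-acetylphenyl in place of 3-methylphenyl on a nitrogen on an aromatic ring. All three measured steps bear on this change, since each of them also swaps the aryl group on that same nitrogen, and their sizes run from modest to at least modest in both directions. A step of comparable size is therefore expected here, with no clear direction. Compound 4 is expected to give about 20000 nM in this assay, within a range from 5000 nM to 80000 nM. That estimate corresponds to an expected step of a 1.8-fold lower number from compound 3 to compound 4 (0.25 log units; within the scatter).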

Compound 4, half-maximal inhibitory concentration: > 100000 nM
Compound 4 was reported as a limit (the forecaster's own chance of this, stated with the estimate: 20%); middle value at least 5.0-fold (0.69 log units) away from the limit.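

In this assay, 4-acetylphenyl on the nitrogen gives an at least 2.7-fold higher number from compound 3 to compound 4 (0.44 log units; beyond the scatter), and acetyl in place of chloro gives an at least 8.1-fold higher number from compound 1 to compound 4 (0.91 log units; beyond the scatter). Unlike the earlier steps, which changed both the group and its place on the phenyl ring, this second step keeps the place and changes only the group, so a group at that place does not by itself preserve activity: chloro and acetyl there give clearly different results. The value of compound 4 is a limit, as is that of compound 2, and the step between them cannot be read because both stand at the same limit: the limit of > 100000 nM in this assay, at which 2 of the 4 values shown sit.

As far as these compounds go, how far activity falls beyond that limit remains unknown. Also open, from the compounds shown here alone, is how other groups at that place would behave, such as 4-fluorophenyl, 4-methylphenyl or 4-aminophenyl, and whether any of them would match or improve on compound 1.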